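Swapping a ring substituent for a methyl on the core

The source may hold more compounds than are shown below. What is called first, only, known or untested is meant among the compounds shown, and "the series" means these compounds.

Of the compounds shown here, three sharing one core have been tested in a functional assay on the whole organism (strain Kunming) with Mus musculus as the target, in the maximal electroshock model, with a stated time of 0.5 h; on this read-out higher numbers stand for an effect only at larger amounts of compound and lower numbers for an effect already at smaller amounts. Compound 1 `O=C1NC2(CC2c2ccc3cccc(OCc4ccccc4)c3n2)C(=O)N1c1ccc(C(F)(F)F)cc1` gives 300 mg/kg, compound 2 `O=C1NC2(CC2c2ccc3cccc(OCc4ccccc4)c3n2)C(=O)N1c1ccc(F)cc1` gives 300 mg/kg, and compound 3 `O=C1NC2(CC2c2ccc3cccc(OCc4ccccc4)c3n2)C(=O)N1C1CCCCC1` gives 300 mg/kg. The three values sit level: no change at the digits printed from compound 1 to compound 2 (within the scatter), no change at the digits printed from compound 1 to compound 3 (within the scatter), and no change at the digits printed from compound 2 to compound 3 (within the scatter). Compound 3 therefore stands together with compounds 1 and 2 on this read-out, neither apart from one nor from the other.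

Compound 4 `CN1C(=O)NC2(CC2c2ccc3cccc(OCc4ccccc4)c3n2)C1=O` has not yet been tested. Compared with compound 3 the change is methyl in place of cyclohexyl on an amide-type nitrogen in a ring. Among the compounds with values here, the steps that bear on this are those that also altered the group on the amide-type nitrogen in the ring: no change at the digits printed from compound 1 to compound 3 (within the scatter) and no change at the digits printed from compound 2 to compound 3 (within the scatter), both within the scatter. The change to compound 4 is at the same nitrogen, so the expectation is a step of no change at the digits printed from compound 3 to compound 4 (within the scatter), that is, nothing beyond the scatter. Compound 4 is therefore estimated at 300 mg/kg, with a range from 150 mg/kg to 600 mg/kg.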

Compound 4, minimum effective dose: 100 mg/kg
Compound 4: middle estimate off by 3.0-fold (0.48 log units), on the high side; the measured number lies below the stated range.
By their numbers in this assay, from the lowest: compound 4; then compounds 1, 2 and 3 (each within the scatter of the next).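

Methyl on the amide-type nitrogen gives a 3.0-fold lower number from compound 3 to compound 4 (0.48 log units; beyond the scatter) and a 3.0-fold lower number from compound 2 to compound 4 (0.48 log units; beyond the scatter) and also a 3.0-fold lower number from compound 1 to compound 4 (0.48 log units; beyond the scatter) in this assay as the first sign that this position can shift the read-out at all. Cyclohexyl, 4-fluorophenyl and 4-(trifluoromethyl)phenyl could not be told apart here, while methyl, the only one of the four groups without a ring, separates from all three. Nothing measured here accounts for this shift.

Within the data shown here, with only one group without a ring, these compounds cannot show whether the lower number belongs to methyl alone or extends to other open chains such as ethyl or a longer chain. From the compounds shown here alone, whether a plain hydrogen on this nitrogen would lower the number further or raise it also remains open.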